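Ester extension at the hydroxymethyl side chain

The compounds below may be only part of what the source reports. "The series", "measured", "known", "first", "only" and "open" are said of these compounds alone.

Compound 1 `COc1nc(C)c(Nc2nc(Cl)cn([C@H](CO)C3CC3)c2=O)cc1C` gives 88 nM in an assay on frontal cortex for displacement of a labelled ligand from corticotropin-releasing factor receptor 1 (Rattus norvegicus), with a stated time of 2 h; a higher number here means a weaker inhibitor, a lower number a stronger inhibitor. Compound 2 `COc1nc(C)c(Nc2nc(Cl)cn([C@H](COC(C)=O)C3CC3)c2=O)cc1C` gives 5.3 nM in this assay, the lowest of the two numbers. Among the measured compounds shown here, the only measured step is a 17-fold lower number from compound 1 to compound 2 (1.22 log units; beyond the scatter), acetyl in place of hydrogen on an oxygen on a saturated carbon. Compound 3 `COc1nc(C)c(Nc2nc(Cl)cn([C@H](COC(=O)c3ccccc3)C3CC3)c2=O)cc1C` carries phenyl in place of methyl on a carbonyl carbon. That step concerns a different change and does not test exchanging methyl for phenyl on the carbonyl carbon, so nothing measured speaks for a shift either way. The step is therefore expected to stay within the scatter, a 1.1-fold higher number from compound 2 to compound 3 (0.05 log units; within the scatter). Compound 3 is estimated at 6 nM in this assay, between 2 nM and 20 nM.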

Compound 3, half-maximal inhibitory concentration: 1.5 nM
The estimate for compound 3 lay 4.0-fold (0.60 log units) above the measured number; measured number below the stated range.
By their numbers in this assay, from the lowest: compound 3; then compound 2; then compound 1.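

The carbonyl carbon of the ester still responds to change: in this assay, phenyl in place of methyl gives a 3.5-fold lower number from compound 2 to compound 3 (0.55 log units; beyond the scatter), so the gain does not end with acetyl. Benzoyl on the side-chain oxygen gives a 59-fold lower number from compound 1 to compound 3 (1.77 log units; beyond the scatter), and most of that distance is already covered by acetyl. Nothing available bears on why the number falls with this change.

Open, from the compounds shown here alone, is whether a saturated ring such as cyclohexyl, or a longer chain, on the carbonyl carbon matches phenyl. Also open, going by these compounds, is how a substituted phenyl such as fluorophenyl, or an amide in place of the ester, compares.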